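Fluoro for methoxy on a melanocortin receptor 4 agonist series

This account rests on a few compounds, and the source may have more. Where it says the series, first, only, none or still open, it means among the compounds named here.

Compound 1 `COc1ccc(N(C(=O)CN2C=CN(c3ccccc3)C(=O)C(Cc3n[nH]c4cc(F)ccc34)C2=O)C(C)C)cc1` gives 355 nM in a functional assay on CHO cells for agonist activity at Melanocortin receptor 4 (Homo sapiens), read by a luciferase reporter, with a stated time of 4 h; a higher number here means that more compound is needed for the effect, a lower number that less compound is needed. Compound 3 `CC(C)N(C(=O)CN1C=CN(c2ccccc2)C(=O)C(Cc2n[nH]c3cc(F)ccc23)C1=O)c1ccc(F)cc1` carries fluoro in place of methoxy on an aromatic carbon; in this assay compound 3 gives 178 nM, a step of a 2.0-fold lower number from compound 1 to compound 3 (0.30 log units; within the scatter). Compound 2 `COc1ccc(N(C(=O)CN2C=CN(c3ccccc3)C(=O)C(Cc3n[nH]c4ccccc34)(OC)C2=O)C(C)C)cc1` rests on a core that differs from that of compound 1 in a way that is not broken down here; in this assay compound 2 gives 166 nM. Compound 4 `COC1(Cc2n[nH]c3ccccc23)C(=O)N(CC(=O)N(c2ccc(F)cc2)C(C)C)C=CN(c2ccccc2)C1=O` is related to compound 2 by the same kind of change, (fluoro in place of methoxy on an aromatic carbon). Because the earlier step of a 2.0-fold lower number from compound 1 to compound 3 (0.30 log units; within the scatter) stayed within the usual scatter, the step from compound 2 to compound 4 is expected to be of similar size, a 1.8-fold lower number from compound 2 to compound 4 (0.27 log units; within the scatter). Compound 4 is therefore estimated at 90 nM, with a likely range from 40 nM to 200 nM in this assay.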

Compound 4, half-maximal effective concentration: 44.7 nM
Compound 4: middle estimate off by 2.0-fold (0.30 log units), on the high side; the measured number falls inside the stated range.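

In this assay, going from 4-methoxyphenyl to 4-fluorophenyl on the second core gives a 3.7-fold lower number from compound 2 to compound 4 (0.57 log units; beyond the scatter). Set beside the step on the core of compound 1, this step cannot be told apart from it: the same change on two cores in this assay, a 2.0-fold lower number (0.30 log units; within the scatter) from compound 1 to compound 3 and a 3.7-fold lower number (0.57 log units; beyond the scatter) from compound 2 to compound 4, 1.9-fold (0.27 log units) apart, within the scatter of two such steps The change therefore carried to a second core with no detectable difference in size, but two pairs cannot show that it would carry to any further core, and they give no sign that the core alters the step.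

The compounds shown hold only methoxy and fluoro at this place on the ring. As far as these compounds go, how a chloro group, a nitrile or an amine would read there remains open, on either core.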